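The source may hold more compounds than are shown below. What is called first, only, known or untested is meant among the compounds shown, and "the series" means these compounds.

Measured compounds:
Compound 1, `COc1cc(/C=C/C(=O)c2cccc(-n3cc(-c4ccc(Cl)cc4)[nH]c3=O)c2)ccc1O`, 2500 nM in a functional assay on SF-268 cells (Homo sapiens) for inhibition; a higher number here means a weaker inhibitor of growth, a lower number a stronger inhibitor of growth.
Compound 2, `COc1cc(/C=C/C(=O)c2cccc(-n3cc(-c4ccccc4)[nH]c3=O)c2)ccc1O`, 2070 nM in this assay.
Compound 3, `COc1ccc(-c2cn(-c3cccc(C(=O)/C=C/c4cc(OC)c(OC)c(OC)c4)c3)c(=O)[nH]2)cc1`, 3210 nM in this assay.

Compound 3 gives a number that lies within the scatter of compound 1 and of compound 2, so the three measured values cannot be told apart. Going by the values given here, the only measured step, a 1.2-fold lower number from compound 1 to compound 2 (0.08 log units; within the scatter), concerns hydrogen in place of chloro on an aromatic carbon and does not touch the part of the molecule that changes here.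

Compound 4, `COc1ccc(-c2cn(-c3cccc(C(=O)/C=C/c4ccc(O)c(OC)c4)c3)c(=O)[nH]2)cc1`, differs from compound 3 by 4-hydroxy-3-methoxyphenyl in place of 3,4,5-trimethoxyphenyl on a double-bonded chain carbon bound to a double-bonded chain carbon. Among the compounds with values here, no measured step bears directly on this change. What the data show is that the two compounds carrying the 4-hydroxy-3-methoxyphenyl on the same double-bonded chain carbon give numbers within the scatter of one another: compound 1 gives 2500 nM, and compound 2 gives 2070 nM. Compound 3 with the 3,4,5-trimethoxyphenyl gives 3210 nM, again within the scatter of both.

Compound 4 is therefore expected to sit among these values, with a step of a 1.3-fold lower number from compound 3 to compound 4 (0.13 log units; within the scatter) that is not expected to exceed the scatter. The estimate for compound 4 in this assay is 2400 nM, with a range from 1200 nM to 5000 nM.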

Compound 4, concentration for 50% growth inhibition: 3400 nM
The estimate for compound 4 lay 1.4-fold (0.15 log units) below the measured number; the range from low to high includes it.
By their numbers in this assay, from the lowest: compounds 2, 1, 3 and 4 (each within the scatter of the next).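

In this assay, going by these compounds alone, the exchange at the double-bonded chain carbon bound to a double-bonded chain carbon now has a measured step: 4-hydroxy-3-methoxyphenyl in place of 3,4,5-trimethoxyphenyl gives a 1.1-fold higher number from compound 3 to compound 4 (0.02 log units; within the scatter), so this change, which the earlier compounds did not address, cannot be told from the scatter. The result also adds two steps on the aromatic carbon at the other end of the molecule, with 4-hydroxy-3-methoxyphenyl held constant on the chain: methoxy in place of hydrogen gives a 1.6-fold higher number from compound 2 to compound 4 (0.22 log units; within the scatter), and methoxy in place of chloro gives a 1.4-fold higher number from compound 1 to compound 4 (0.13 log units; within the scatter). Hydrogen, chloro and methoxy on that aromatic carbon therefore cannot be told apart in this series, and no measured step at either site goes beyond the scatter.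

The compounds shown leave open whether a phenyl carrying an amine or a carboxylic acid on the double-bonded chain carbon, or a longer alkoxy chain in place of methoxy on the aromatic carbon, would move the number beyond the scatter. Nothing available accounts for how little the number moves across these changes.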